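The source may report more compounds than this note shows. Statements on the series, on what has been measured and on what is new or still open speak of the compounds shown alone.

Measured so far in a functional assay on T-24 cells (Homo sapiens) for antiproliferative activity, read by MTT assay, with a stated time of 48 h; a lower number here means a stronger inhibitor, a higher number a weaker inhibitor:
compound 1, `O=C(Nc1cccc(Cl)c1)Nc1cccc(CNc2nccnc2Cl)c1`: 6810 nM
compound 2, `Cc1ccc(NC(=O)Nc2cccc(CNc3nccnc3Cl)c2)c(C)c1`: 9230 nM
compound 3, `O=C(Nc1cccc(CNc2nccnc2Cl)c1)NC1CCCCC1`: for compound 3 the assay gives only a limit, > 40000 nM

Three compounds share one core and differ only in the group on an amide-type nitrogen of the urea. Compound 1 gives the lowest of the two plain numbers, and compound 2 sits close to it: the step of a 1.4-fold higher number from compound 1 to compound 2 (0.13 log units; within the scatter) stays within the scatter, so the two cannot be ranked. Swapping the aromatic ring for a saturated one costs clearly: an at least 5.8-fold higher number from compound 1 to compound 3 (0.76 log units; beyond the scatter) and an at least 4.3-fold higher number from compound 2 to compound 3 (0.63 log units; beyond the scatter) are both beyond the scatter, though only as limits, because compound 3 sits at the limit of > 40000 nM in this assay, at which 1 of the 3 values shown sits.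

The unmeasured compound 4, `Cc1ccc(NC(=O)Nc2cccc(CNc3nccnc3Cl)c2)cc1`, differs from compound 1 in this way: 4-methylphenyl in place of 3-chlorophenyl on an amide-type nitrogen. Among the measured compounds shown here, it keeps an aromatic ring on that nitrogen, so the step that bears on it is the one between two aryl groups, compound 1 to compound 2, which did not move the number beyond the scatter. The steps to compound 3 concern the loss of the aromatic ring and do not apply here.

In this assay compound 4 is therefore expected to give about 8000 nM, in the range 4000 nM to 16000 nM. The expected step of a 1.2-fold higher number from compound 1 to compound 4 (0.07 log units; within the scatter) is estimated to stay within the scatter.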

Compound 4, half-maximal inhibitory concentration: 9820 nM
For compound 4 the middle estimate is 1.2-fold (0.09 log units) below the measured one; the measured number falls inside the stated range.
By their numbers in this assay, from the lowest: compounds 1, 2 and 4 (each within the scatter of the next). At a limit, above all of these: compound 3.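

In this assay, among the compounds shown here, the step of a 1.4-fold higher number from compound 1 to compound 4 (0.16 log units; within the scatter) stays within the scatter, as does the step of a 1.1-fold higher number from compound 2 to compound 4 (0.03 log units; within the scatter), so neither exchanging 3-chlorophenyl for 4-methylphenyl on this nitrogen nor the single change of hydrogen in place of methyl on an aromatic carbon separates these compounds. With a third aromatic group now in hand, the step of an at least 4.0-fold lower number from compound 3 to compound 4 (0.60 log units; beyond the scatter) lies beyond the scatter, so the gap to the cyclohexyl compound appears with each of the three aromatic groups shown, and no compound among them goes against it. Compound 3 gives only a limit and not a number, so the true size of that gap stays unknown: the limit of > 40000 nM in this assay, at which 1 of the 4 values shown sits.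

The compounds shown leave open whether a different kind of group on the aromatic ring, such as an amine or a carboxylic acid, would move the number beyond the scatter. They also leave open whether an open chain such as n-butyl on this nitrogen would give a number like that of the aromatic groups or a limit like that of cyclohexyl.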